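The source may report more compounds than this note shows. Statements on the series, on what has been measured and on what is new or still open speak of the compounds shown alone.

Compound 1, whose structure is `CCCc1cnc(Nc2cc[nH]n2)n2c(CCC)nc(C)c12`, was tested in a functional assay for inhibition, with Homo sapiens as the target; a higher number here means a weaker inhibitor, a lower number a stronger inhibitor. In this assay compound 1 gives > 48000 nM, which is a limit of the assay and not a measured number. Compound 1 therefore stands at the limit of > 48000 nM in this assay, at which 1 of the 2 values shown sits, so its true potency is known only to be weak. A second, structurally unrelated compound, compound 2 with the structure `C=CCSc1nncc2cnc(COC)n12`, also reached this assay; in this assay compound 2 gives 79000 nM, a number in the same weak region.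

The step of interest leads from compound 1 to compound 3, whose structure is `CCCc1nc(C)c2c(CC)cnc(Nc3cc[nH]n3)n12`. The change is small: hydrogen in place of methyl on a saturated chain carbon, two bonds along the chain from an aromatic carbon, so one chain on the shared core of compound 1 becomes shorter. Removing a single chain carbon from a compound that already shows only a limit gives little reason to expect a large shift, and no comparable pair measured here shows one, so the step is expected to lie within the usual scatter or close to it. The estimated step that the limit leaves unreadable from compound 1 to compound 3 reflects this expectation. Compound 3 is therefore expected to give about 60000 nM in this assay, in a range from 20000 nM to 200000 nM, most likely again reported only as a limit.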

Compound 3, half-maximal inhibitory concentration: > 48000 nM
Compound 3: no number, only a limit; the forecaster's own chance of this, stated with the estimate: 75%; the middle value lies beyond the limit too.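

In this assay compound 3 gives > 48000 nM, which is a limit of the assay and not a number. Compound 1 also shows only a limit, so no step can be read between compound 1 and compound 3. The compounds shown leave open how potent both truly are, and whether shortening the propyl chain to ethyl changes that potency at all.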